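Swapping iodine for trifluoromethoxy on the anilino ring

The source may hold more compounds than are shown below. What is called first, only, known or untested is meant among the compounds shown, and "the series" means these compounds.

Measured so far:
Compound 1, `CCCCCOC1=C(C(=O)c2ccccc2)C(c2ccc(Br)cc2)N(CCCn2ccnc2)C1=O`; in a functional assay on NCI-H1299 cells (Homo sapiens) for antiproliferative activity, read by MTT assay, with a stated time of 72 h (on this read-out higher numbers stand for weaker inhibition and lower numbers for stronger inhibition), compound 1 gives 10300 nM.
Compound 2, `O=C(C1=C(Nc2ccc(I)cc2)C(=O)N(CCCn2ccnc2)C1c1ccc(Br)cc1)c1ccccc1`; in this assay compound 2 gives 19400 nM.

Among the measured compounds shown here, compound 2 has the higher of the two numbers, but its only neighbour is compound 1, and the single measured step, a 1.9-fold higher number from compound 1 to compound 2 (0.27 log units; within the scatter), lies within the scatter, so the two compounds cannot be told apart on these data. That step concerns the group on the double-bonded ring carbon, where a pentyloxy group was replaced by an anilino group.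

Compound 3, `O=C(C1=C(Nc2ccc(OC(F)(F)F)cc2)C(=O)N(CCCn2ccnc2)C1c1ccc(Br)cc1)c1ccccc1`, keeps the whole shared core of compound 2 and alters only the outer ring of that anilino group: trifluoromethoxy in place of iodo on an aromatic carbon. For the measured compounds named here, no measured step touches this ring, so nothing in the data speaks for a shift in either direction, and the one step that is known was itself within the scatter. The expectation is therefore no change beyond the scatter in this assay, a step of a 1.0-fold lower number from compound 2 to compound 3 (0.01 log units; within the scatter). Compound 3 is estimated at 19000 nM, with a likely range from 7000 nM to 50000 nM.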

Compound 3, half-maximal inhibitory concentration: 11500 nM
Beside the measured number, compound 3's estimate is 1.7-fold (0.22 log units) above it; the range from low to high includes it.
By their numbers in this assay, from the lowest: compounds 1, 3 and 2 (each within the scatter of the next).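

In this assay, the first exchange measured on the outer ring of the anilino group, trifluoromethoxy in place of iodo, gives a 1.7-fold lower number from compound 2 to compound 3 (0.23 log units; within the scatter) and so cannot be told apart from no effect. On an aromatic carbon para to a large group, a single iodine atom and a group of five heavy atoms that brings one hydrogen-bond acceptor therefore give readings this assay does not separate. Going back to the double-bonded ring carbon, the second anilino compound gives a 1.1-fold higher number from compound 1 to compound 3 (0.05 log units; within the scatter) and the first gives a 1.9-fold higher number from compound 1 to compound 2 (0.27 log units; within the scatter), so neither anilino group can be told apart from pentyloxy, and no measurement on these compounds offers an explanation for any of these results.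

Still open, on these data alone, is whether any group on this aromatic ring can move the number beyond the scatter, for example a carboxylic acid or an amine in place of the trifluoromethoxy group. Also open, as far as these compounds go, is how a shorter alkoxy chain, such as methoxy, or a simple unsubstituted anilino group would read on the double-bonded ring carbon.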